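The source may hold more compounds than are shown below. What is called first, only, known or untested is meant among the compounds shown, and "the series" means these compounds.

Measured so far in an assay on HEK293 cells for displacement of a labelled ligand from NPC1-like intracellular cholesterol transporter 1 (Homo sapiens); a higher number here means a weaker inhibitor, a lower number a stronger inhibitor:
Compound 1 `CC(C)(C)OC(=O)NCCNC(=O)CN1CN(c2ccccc2)C2(CCN(C(=O)c3ccc(C(C)(C)C)cc3)CC2)C1=O`: 10900 nM
Compound 2 `CC(C)(C)OC(=O)NCCNC(=O)CN1CN(c2ccccc2)C2(CCN(C(=O)c3ccc(C4CCCCC4)cc3)CC2)C1=O`: 5500 nM
Compound 3 `CC(C)(C)OC(=O)NCC1CCCN(C(=O)CN2CN(c3ccccc3)C3(CCN(C(=O)c4ccc(C(C)(C)C)cc4)CC3)C2=O)C1`: 9500 nM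

Compound 2 has the lowest of the three numbers, yet the step of a 2.0-fold lower number from compound 1 to compound 2 (0.30 log units; within the scatter) stays within the scatter, and its gap to compound 3 is of the same size, so the three compounds cannot be told apart. Compound 4 `COC(=O)CCNC(=O)CN1CN(c2ccccc2)C2(CCN(C(=O)c3ccc(C4CCCCC4)cc3)CC2)C1=O` is compound 2 altered at the chain end: methoxycarbonyl in place of (tert-butoxycarbonyl)amino on a saturated chain carbon, two bonds along the chain from an amide-type nitrogen. Within the data shown here, no measured step changes this part of the molecule; the only step known, a 2.0-fold lower number from compound 1 to compound 2 (0.30 log units; within the scatter), concerns the group on the aromatic carbon. Compounds 1 and 3 simply give values close to each other. The expected step is therefore a 1.2-fold higher number from compound 2 to compound 4 (0.07 log units; within the scatter), nothing beyond the scatter. In this assay compound 4 is estimated at 6500 nM, between 2500 nM and 20000 nM.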

Compound 4, half-maximal inhibitory concentration: 12900 nM
The estimate for compound 4 lay 2.0-fold (0.30 log units) below the measured number; measured number inside the range.
By their numbers in this assay, from the lowest: compounds 2, 3, 1 and 4 (each within the scatter of the next, the first and the last beyond it).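

The step of a 2.3-fold higher number from compound 2 to compound 4 (0.37 log units; beyond the scatter) shows that in this assay the chain end does matter, if modestly: replacing (tert-butoxycarbonyl)amino with methoxycarbonyl at this position is the first single change shown to pass beyond the scatter. The change goes from 8 heavy atoms to 4 and from 1 hydrogen-bond donor to 0, so this one pair cannot separate the two differences. Going by these compounds, how a carboxylic acid, a free amine or a longer chain would behave at this chain end stays open. No measurement here gives a reason for the step.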